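The source may hold more compounds than are shown below. What is called first, only, known or untested is meant among the compounds shown, and "the series" means these compounds.

Compound 1 `Fc1ccc(/C=C\c2cc3ccccc3nc2Cl)cc1`: in a functional assay on MDA-MB-468 cells (Homo sapiens) for antiproliferative activity, read by sulforhodamine B assay, with a stated time of 72 h (on this read-out lower numbers stand for stronger inhibition and higher numbers for weaker inhibition), compound 1 gives 5290 nM.
Compound 2 `Fc1ccc(/C=C\c2cc3ccc(Cl)cc3nc2Cl)cc1`: in this assay compound 2 gives 10900 nM.
Compound 3 `FC(F)(F)c1cc(/C=C\c2cc3ccccc3nc2Cl)cc(C(F)(F)F)c1`: in this assay compound 3 gives 10500 nM.

Compound 4 `FC(F)(F)c1cc(/C=C\c2cc3ccc(Cl)cc3nc2Cl)cc(C(F)(F)F)c1` has not yet been measured in this assay. It differs from compound 3 in one place: chloro in place of hydrogen on an aromatic carbon. The same change has already been made once among the measured compounds, from compound 1 to compound 2: chloro in place of hydrogen on an aromatic carbon. There it produced a 2.1-fold higher number from compound 1 to compound 2 (0.31 log units; beyond the scatter). The place of the change is the same in both pairs, so this is the same change on two different cores; how the core of compound 1 and the core of compound 3 differ is not broken down here. The values of compound 2 and compound 3 lie within the scatter of each other, and compound 1 and compound 3 are also within the scatter of each other in this assay.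

Because the step of a 2.1-fold higher number from compound 1 to compound 2 (0.31 log units; beyond the scatter) was measured for the same change at the same place, a step of similar size and direction is expected here, a 1.9-fold higher number from compound 3 to compound 4 (0.28 log units; within the scatter), though one measured pair is a thin basis. Compound 4 is therefore estimated at 20000 nM in this assay, with a likely range from 8000 nM to 50000 nM.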

Compound 4, half-maximal inhibitory concentration: > 50000 nM
Compound 4 ended at the assay's limit; the forecaster's own chance of this, stated with the estimate: 10%; middle value at least 2.5-fold (0.39 log units) from the limit.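

In this assay, chloro in place of hydrogen on an aromatic carbon gave a higher number on the first core, and on the second core it again moved the same way, with an at least 4.7-fold higher number from compound 3 to compound 4 (0.67 log units; beyond the scatter). Compound 4 gives > 50000 nM, which is a limit of the assay and not a number. The direction of the change therefore carried over in these two pairs, but they do not show how large the step is on the second core or whether its size depends on the core: the same change on two cores in this assay, a 2.1-fold higher number (0.31 log units; beyond the scatter) from compound 1 to compound 2 and an at least 4.7-fold higher number (0.67 log units; beyond the scatter) from compound 3 to compound 4; the limit leaves it open whether they differ

The compounds shown leave open whether a bromo, a methoxy or an amine at this same place would shift the number in the same direction on both cores. They also leave open whether the chloro step would hold on a core with an amine or a carboxylic acid in place of the two trifluoromethyl groups.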